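Removing the Allyl Group from Compound 2

A few compounds are considered here, and "the series" means these few. Any claim that something is new, unique, unknown or untested is made for them only; others in the source may bear on it.

Compound 2 `C=CCn1c(=O)n(C(=O)NCCN2CCN(C)CC2)c2ccccc21` gives the higher of the two numbers reported in a functional assay for agonist activity at 5-hydroxytryptamine receptor 4 (Cavia porcellus) (on this read-out lower numbers stand for smaller maximal responses and higher numbers for larger maximal responses), with 0.63. Compound 1 `CN1CCN(CNC(=O)n2c(=O)n(C3CC3)c3ccccc32)CC1` gives 0.53 in this assay, a gap to compound 2 that lies within the usual scatter. For compound 3 `COc1ccc2c(c1)n(C(=O)NCCN1CCN(C)CC1)c(=O)n2C(C)C` only a limit is known: in this assay compound 3 gives < 0.3, which is the limit of < 0.3 in this assay, at which 1 of the 3 values shown sits. Compound 4 `CN1CCN(CCNC(=O)n2c(=O)[nH]c3ccccc32)CC1` has not yet been measured. It differs from compound 2 by hydrogen in place of allyl on an aromatic nitrogen. Within the data shown here, with no measured step of a single change to guide the size, the chemist expects in this assay a change from compound 2 to compound 4 that stays near the scatter, possibly a modest drop. The estimate for compound 4 is 0.5, between 0.3 and 0.72. That estimate means an expected step of a number 0.13 lower from compound 2 to compound 4 (beyond the scatter).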

Compound 4, intrinsic activity: the largest response reached, as a fraction of the reference agonist's: 0.35
The estimate for compound 4 lay 0.15 above the measured number; measured number inside the range.
By their numbers in this assay, from the lowest: compound 4; then compounds 1 and 2 (each within the scatter of the next). At a limit, below all of these: compound 3.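

Among these compounds, on this aromatic nitrogen, hydrogen in place of allyl gives a number 0.28 lower from compound 2 to compound 4 (beyond the scatter) in this assay and is the only single change at this position that can be read. Among the compounds shown here, the response does not vanish without the allyl group, but the allyl group clearly counts for more here than the earlier compounds could show. Compound 3 stays a limit and not a number: the limit of < 0.3 in this assay, at which 1 of the 4 values shown sits.

On these data alone, whether the step follows from the double bond or from the carbons of the allyl group stays open. A propyl group on this nitrogen would separate the two.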